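From Chloro to Bromo on a Shared Core

A few compounds are considered here, and "the series" means these few. Any claim that something is new, unique, unknown or untested is made for them only; others in the source may bear on it.

In a functional assay on MDA-MB-468 cells (Homo sapiens) for antiproliferative activity (a lower number here means a stronger inhibitor of growth, a higher number a weaker inhibitor of growth), compound 1 `COc1ccc(-c2nc3cc(F)ccc3s2)cc1OC` gives < 0.1 nM, which is a limit of the assay and not a number. Going by the values given here, compound 2 `COc1ccc(-c2nc3cc(Cl)ccc3s2)cc1OC` gives 1000 nM, the only true number so far. Among the compounds with values here, the one measured step is large: an at least 10000-fold higher number from compound 1 to compound 2 (4.00 log units; beyond the scatter), with chloro in place of fluoro. Compound 3 `COc1ccc(-c2nc3cc(Br)ccc3s2)cc1OC` changes the same aromatic carbon again: bromo in place of chloro on an aromatic carbon. That single step starts from a limit and sets no firm size for this change, so margins stay wide. The estimated step in this assay is a 1.5-fold higher number from compound 2 to compound 3 (0.18 log units; within the scatter), with nothing expected beyond the scatter. Compound 3 is estimated at 1500 nM, within an expected range of 200 nM to 10000 nM.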

Compound 3, concentration for 50% growth inhibition: 770 nM
Compound 3: middle estimate off by 1.9-fold (0.29 log units), on the high side; low and high end bracket the measured number.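

In this assay, bromo and chloro cannot be told apart on this aromatic carbon, with a 1.3-fold lower number from compound 2 to compound 3 (0.11 log units; within the scatter) as the step between them. The large gap from the fluoro compound is seen with bromo as well, with an at least 7700-fold higher number from compound 1 to compound 3 (3.88 log units; beyond the scatter) on this change, so it is not confined to chloro. The value of compound 1 is a limit and not a number: the limit of < 0.1 nM in this assay, at which 1 of the 3 values shown sits.

Going by these compounds, what the shared core does with only hydrogen on this carbon stays open. So does the effect of an amine or a nitrile in the same place.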